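This account rests on a few compounds, and the source may have more. Where it says the series, first, only, none or still open, it means among the compounds named here.

Working notes on the series, all read in an ADME assay on the whole organism (Mus musculus, strain CD-1) for pharmacokinetics; on this read-out higher numbers stand for fast clearance and lower numbers for slow clearance. Compound 1 (`COc1cc([C@](O)(CCN(C)C)[C@@H](c2cc3cc(C#N)ccc3nc2OC)c2cccc(C)c2F)cc(OC(F)F)n1`) gives 13 mL/min/kg, compound 2 (`COc1cccc([C@H](c2cc3cc(Br)ccc3nc2OC)[C@@](O)(CCN(C)C)c2cc(SC)nc(SC)c2)c1F`) gives 13 mL/min/kg, and compound 3 (`COc1cccc([C@H](c2cc3cc(C#N)ccc3nc2OC)[C@@](O)(CCN(C)C)c2cc(SC)nc(SC)c2)c1F`) gives 44 mL/min/kg. Compound 3 therefore holds the highest of the three numbers, beyond the scatter from both of the others.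

Next in line is compound 4 (`COc1nc2ccc(C#N)cc2cc1[C@@H](c1cccc(C)c1F)[C@@](O)(CCN(C)C)c1cc(SC)nc(SC)c1`), which differs from compound 3 in one place: methyl in place of methoxy on an aromatic carbon. This is methyl in place of methoxy on an aromatic carbon, or 2-fluoro-3-methoxyphenyl to 2-fluoro-3-methylphenyl.

Among the measured compounds shown here, no measured step covers this change. For the measured compounds named here, the only single-place step is a 3.4-fold higher number from compound 2 to compound 3 (0.53 log units; beyond the scatter), a modest one, with cyano in place of bromo. It bears only indirectly: it shows the size one substituent swap has reached in this series, but it gives no direction for methoxy to methyl.

A step of similar size is possible in either direction, though none beyond the scatter is the working expectation. Going by the values given here, with compound 3 at 44 mL/min/kg, the top of the numbers so far, a weak lean downward is expected. The expected change is a 1.4-fold lower number from compound 3 to compound 4 (0.14 log units; within the scatter), which is within the scatter. The estimate for compound 4 is 32 mL/min/kg, with an expected range of 14 mL/min/kg to 75 mL/min/kg.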

Compound 4, clearance: 22 mL/min/kg
Estimate against measurement, compound 4: 1.5-fold (0.16 log units) above; the range from low to high includes it.
By their numbers in this assay, from the lowest: compounds 1, 2, 4 and 3 (each within the scatter of the next, the first and the last beyond it).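

In this assay the change from 2-fluoro-3-methoxyphenyl to 2-fluoro-3-methylphenyl now has a reading of its own, and the step is a 2.0-fold lower number from compound 3 to compound 4 (0.30 log units; within the scatter); for this pair, then, methyl in place of methoxy on an aromatic carbon, ortho to a fluoro group, leaves the number within the scatter. Among the compounds shown here, compound 4 also gives the first one-place reading of the group on the saturated chain carbon: with the group of 10 heavy atoms in place of the group of 12 heavy atoms, there is a 1.7-fold higher number from compound 1 to compound 4 (0.23 log units; within the scatter), again a step that does not pass the scatter. Nothing on hand speaks to what lies behind either step.

The compounds shown leave open how a chloro, ethyl or trifluoromethyl group would read at the place held by methoxy and methyl, since this single pair gives no trend across substituents. Also open, as far as these compounds go, is whether cyano in place of bromo would give a step of the same size with the 2-fluoro-3-methylphenyl group in place, as that step is read only with the 2-fluoro-3-methoxyphenyl group.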